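Replacing the hexyl chain of compound 1 with a dimethylaminomethyl group

The source may report more compounds than this note shows. Statements on the series, on what has been measured and on what is new or still open speak of the compounds shown alone.

Measured compounds:
compound 1, `CCCCCCc1c(F)c(N)c2c(=O)cc(-c3ccc(N)c(F)c3)oc2c1F`, 21000 nM
compound 2, `Nc1ccc(-c2cc(=O)c3c(N)c(F)c(O)c(F)c3o2)cc1F`, > 100000 nM

In a functional assay on HeLa cells (Homo sapiens) for cytotoxicity, read by neutral red uptake, with a stated time of 3 days (a lower number here means a stronger inhibitor, a higher number a weaker inhibitor), compound 1 gives 21000 nM, the only plain number shown. Compound 2, `Nc1ccc(-c2cc(=O)c3c(N)c(F)c(O)c(F)c3o2)cc1F`, reaches only the limit of > 100000 nM, which is a limit of the assay and not a number; it is described by the limit of > 100000 nM in this assay, at which 1 of the 2 values shown sits. For the measured compounds named here, the one measured step, an at least 4.7-fold higher number from compound 1 to compound 2 (0.67 log units; beyond the scatter), shows that losing the hexyl chain for a hydroxy group weakens the compound beyond the scatter.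

Compound 3 is `CN(C)Cc1c(F)c(N)c2c(=O)cc(-c3ccc(N)c(F)c3)oc2c1F`. Its change from compound 1 is dimethylamino in place of pentyl on a saturated chain carbon bound to an aromatic carbon. Going by the values given here, the only step that bears on it, an at least 4.7-fold higher number from compound 1 to compound 2 (0.67 log units; beyond the scatter), also removes most of the chain, so a weakening is expected for compound 3, though a smaller one since part of the chain remains. The expected step is a 2.9-fold higher number from compound 1 to compound 3 (0.46 log units; beyond the scatter). Compound 3 is estimated at 60000 nM, within 20000 nM to 200000 nM.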

Compound 3, half-maximal inhibitory concentration: 8900 nM
Estimate against measurement, compound 3: 6.7-fold (0.83 log units) above; the measured number lies below the stated range.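

In this assay, the place on a saturated chain carbon bound to an aromatic carbon accepts a nitrogen group: dimethylamino in place of pentyl gives a 2.4-fold lower number from compound 1 to compound 3 (0.37 log units; beyond the scatter), so here the hexyl chain is not needed for the stronger number, and the smaller group goes with a stronger compound. Where hydroxy had weakened the compound, (dimethylamino)methyl gives an at least 11-fold lower number from compound 2 to compound 3 (1.05 log units; beyond the scatter). The size of that step rests on a limit of the assay, not a number, held by compound 2: the limit of > 100000 nM in this assay, at which 1 of the 3 values shown sits.

The compounds shown leave open whether the nitrogen itself goes with the stronger number or whether a plain methyl or ethyl group would do as well. They also leave open how a longer chain ending in dimethylamino, a morpholine or a carboxylic acid would read in this place.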